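Ring Contraction on the Amine Side Chain

The source may report more compounds than this note shows. Statements on the series, on what has been measured and on what is new or still open speak of the compounds shown alone.

Compound 2 `COCc1cc(OC)c(-c2csc3c(N(CC4CC4)CC4CCCOC4)c(OC)nn23)c(OC)c1` gives 50 nM in an assay on HEK293 cells for displacement of a labelled ligand from corticotropin-releasing factor receptor 1 (Homo sapiens), read by scintillation proximity assay, with a stated time of 2 h; on this read-out lower numbers stand for stronger inhibition and higher numbers for weaker inhibition. That is the lowest of the two numbers measured, but it cannot be separated from its neighbour: compound 1 `COCc1cc(OC)c(-c2csc3c(N(CC4CCOCC4)CC4CC4)c(OC)nn23)c(OC)c1` gives 69 nM in this assay, and the step of a 1.4-fold lower number from compound 1 to compound 2 (0.14 log units; within the scatter) lies within the scatter. That step exchanged oxan-4-yl for oxan-3-yl on a saturated chain carbon bound to a nitrogen on an aromatic ring, keeping the ring size.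

Compound 3 `COCc1cc(OC)c(-c2csc3c(N(CC4CC4)CC4CCOC4)c(OC)nn23)c(OC)c1` has not yet been measured. It differs from compound 2 by oxolan-3-yl in place of oxan-3-yl on a saturated chain carbon bound to a nitrogen on an aromatic ring; cut one bond further out, the change reads (oxan-3-yl)methyl to (oxolan-3-yl)methyl. For the measured compounds named here, the only measured step touching this part of the molecule is a 1.4-fold lower number from compound 1 to compound 2 (0.14 log units; within the scatter), a change on the same ring that stayed within the scatter. Going by the values given here, no measured pair speaks to the ring contraction itself. One therefore expects compound 3 to show a 1.2-fold higher number from compound 2 to compound 3 (0.08 log units; within the scatter) in this assay, a shift not beyond the scatter. The estimate for compound 3 is 60 nM, with a range from 25 nM to 150 nM.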

Compound 3, half-maximal inhibitory concentration: 48 nM
Beside the measured number, compound 3's estimate is 1.3-fold (0.10 log units) above it; the range from low to high includes it.
By their numbers in this assay, from the lowest: compounds 3, 2 and 1 (each within the scatter of the next).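

For the compounds shown here, the ring contraction is read here for the first time: in this assay there is a 1.0-fold lower number from compound 2 to compound 3 (0.02 log units; within the scatter) when the six-membered oxan-3-yl ring gives way to the five-membered oxolan-3-yl ring on a saturated chain carbon bound to a nitrogen on an aromatic ring. The change from oxan-4-yl to oxolan-3-yl at this same place gives a 1.4-fold lower number from compound 1 to compound 3 (0.16 log units; within the scatter) and so also stays within the scatter, which means that across compound 1, compound 2 and compound 3 neither ring size nor the change of ring attachment yields a difference that can be told apart, and none of the three goes against this. No supporting data bear on this result, and the flat response therefore remains unexplained.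

All three compounds carry a non-aromatic ring with a single oxygen as its hetero atom, so the compounds shown leave open whether that oxygen matters at all, a question that a cyclopentyl ring or a pyrrolidine amine at this place would address. They also leave open how far the ring can shrink or open, as an oxetan-3-yl ring or a 2-methoxyethyl chain would show.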